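Chloro for trifluoromethyl on a urea-linked pyrazole series

The source may hold more compounds than are shown below. What is called first, only, known or untested is meant among the compounds shown, and "the series" means these compounds.

Compounds measured so far:
compound 1 `COc1cc(Cl)cc(-c2nn(-c3cccc(NC(=O)c4ccc(Cl)c(Cl)c4)c3)cc2-c2ccncc2)c1` gives 63.6%
compound 2 `O=C(Nc1cccc(-n2cc(-c3ccncc3)c(-c3cc(O)cc(Cl)c3)n2)c1)Nc1ccc(Cl)c(Cl)c1` gives -6.42%
compound 3 `COc1cc(Cl)cc(-c2nn(-c3cccc(NC(=O)Nc4ccc(Cl)c(C(F)(F)F)c4)c3)cc2-c2ccncc2)c1` gives 14.6%

Of the three numbers in a functional assay on Hs-578T cells (Homo sapiens) for inhibition, read by sulforhodamine B assay, with a stated time of 48 h, tested at 10 uM (on this read-out higher numbers stand for a weaker effect at the one concentration tested and lower numbers for a stronger effect), compound 3 stands second highest. Its nearest neighbour is compound 2, whose number lies lower by a step beyond the scatter, and its furthest is compound 1, whose number lies higher by a step beyond the scatter.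

Compound 4 `COc1cc(Cl)cc(-c2nn(-c3cccc(NC(=O)Nc4ccc(Cl)c(Cl)c4)c3)cc2-c2ccncc2)c1` has not yet been measured. It differs from compound 3 in one place: chloro in place of trifluoromethyl on an aromatic carbon.

Among the measured compounds shown here, one measured step bears on this change, though only in part. From compound 1 to compound 3 the read-out moved a number 49 percentage points lower from compound 1 to compound 3 (beyond the scatter), but that step swaps a 3,4-dichlorophenyl on a carbonyl carbon for a (4-chloro-3-(trifluoromethyl)phenyl)amino group, so the urea linkage and the trifluoromethyl entered together. For the measured compounds named here, compound 2 carries the same (3,4-dichlorophenyl)amino group that compound 4 will carry, and compound 2 gives a number lower than compound 3 beyond the scatter; no step between compound 2 and compound 4 is counted, so their two numbers speak only for themselves. The expected step from compound 3 to compound 4 is therefore a modest move downward, a number 7.6 percentage points lower from compound 3 to compound 4 (within the scatter), not clearly beyond the scatter. Compound 4 is estimated to give 7%, in the range -15% to 30%.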

Compound 4, a percentage reported as activity, at one concentration (the size of the read-out at that concentration, not a potency): 28.5%
Compound 4: the middle estimate sits 21.5 percentage points below what was measured; measured number inside the range.
By their numbers in this assay, from the lowest: compound 2; then compound 3; then compound 4; then compound 1.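

In this assay, the change from trifluoromethyl to chloro on an aromatic carbon, ortho to a chloro group, now has a step of its own with the urea held constant: the read-out gives a number 13.9 percentage points higher from compound 3 to compound 4 (beyond the scatter) and so the step is modest but beyond the scatter. The step from the amide to the urea can now be read apart from that change, with a number 35.1 percentage points lower from compound 1 to compound 4 (beyond the scatter) as a large move, and the same 3,4-dichlorophenyl urea also responds strongly to methyl in place of hydrogen on the oxygen on the aromatic ring, with a number 34.9 percentage points higher from compound 2 to compound 4 (beyond the scatter) as a second large move. No measurement offered here explains any of these steps.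

On these data alone, the trifluoromethyl-to-chloro change rests on a single pair, so whether it has the same direction and size in the hydroxy series of compound 2 remains open. Also open, as far as these compounds go, is how a nitrile, a methyl or a bromo on that aromatic carbon would read in this assay, set against the trifluoromethyl of compound 3 and the chloro of compound 4.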